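This account rests on a few compounds, and the source may have more. Where it says the series, first, only, none or still open, it means among the compounds named here.

Compound 1 `Cc1oc2c([C@H]3CCN(C)C[C@H]3O)c(O)cc(O)c2c(=O)c1C(O)c1ccccc1Br`: 52%
Compound 2 `COc1ccc(C(O)c2c(C)oc3c([C@H]4CCN(C)C[C@H]4O)c(O)cc(O)c3c2=O)cc1Br`: 23%

Both were tested in a functional assay on HL-60 cells (Homo sapiens) for inhibition, read by MTT assay, with a stated time of 48 h, tested at 10 uM (on this read-out higher numbers stand for more inhibition of growth at the one concentration tested and lower numbers for less inhibition of growth), where compound 2 stands lowest of the two at 23%. Compound 3 `Cc1oc2c([C@H]3CCN(C)C[C@H]3O)c(O)cc(O)c2c(=O)c1C(O)c1cccc(Cl)c1Cl` differs from it in one place: 2,3-dichlorophenyl in place of 3-bromo-4-methoxyphenyl on a saturated chain carbon bound to an aromatic carbon and an oxygen on a saturated carbon. Among the compounds with values here, the only measured step at that place is a number 29 percentage points lower from compound 1 to compound 2 (beyond the scatter), which is beyond the scatter. The 2,3-dichlorophenyl resembles the 2-bromophenyl of compound 1, at 52%, more than it resembles the group it replaces, so a rise of similar or somewhat smaller size is expected. The expected change is a number 22 percentage points higher from compound 2 to compound 3 (beyond the scatter). For compound 3 the estimated value is 45%, with an expected range of 25% to 65%.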

Compound 3, percent growth inhibition at one concentration: 12%
Compound 3: the middle estimate sits 33 percentage points above what was measured; the measured number lies below the stated range.
By their numbers in this assay, from the lowest: compound 3; then compound 2; then compound 1.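

In this assay the fall at this position is no longer tied to a ring bearing a methoxy group: the 2,3-dichlorophenyl group, with only halogens on the ring, gives a number 11 percentage points lower from compound 2 to compound 3 (beyond the scatter) and also a number 40 percentage points lower from compound 1 to compound 3 (beyond the scatter). Halogens on the phenyl ring therefore do not by themselves hold the level of compound 1, and the 2-bromophenyl group stands highest of the three.

No measurement at hand explains why the two chlorines and the single bromine part so widely. Going by these compounds, it stays open how an unsubstituted phenyl, or a phenyl carrying an amine, would read at this place.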